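Dropping the 3,3-Diethoxypropyl Group on the Ring Nitrogen

The compounds below may be only part of what the source reports. "The series", "measured", "known", "first", "only" and "open" are said of these compounds alone.

Compound 1 `Cn1c(Cc2nn(C)c(=O)c3ccccc23)nnc1SCC(=O)Nc1ccc(Cl)cc1Cl` gives 21100 nM in an assay on 32D cells for inhibition of interleukin-15 (Mus musculus), read by resazurin assay, with stated times of 30 min and 2.5 days, in the presence of a further agent that is not named here; on this read-out lower numbers stand for stronger inhibition and higher numbers for weaker inhibition.
Compound 2 `CCOC(CCn1c(Cc2nn(C)c(=O)c3ccccc23)nnc1SCC(=O)Nc1ccc(Cl)cc1Cl)OCC` reaches only a limit of the assay, > 30000 nM.
Compound 3 `CCOC(CCn1c(Cc2nn(C)c(=O)c3ccccc23)nnc1SCCCCCCCC(=O)Nc1ccc(Cl)cc1Cl)OCC` gives 16400 nM.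

Among these three, compound 3 carries the lowest number in this assay; its nearest neighbour is compound 1, whose value sits within the usual scatter of it, and compound 2 adds only a limit. Compound 4 `Cn1nc(Cc2nnc(SCCCCCCCC(=O)Nc3ccc(Cl)cc3Cl)[nH]2)c2ccccc2c1=O` has not yet been measured. It differs from compound 3 in one place: hydrogen in place of 3,3-diethoxypropyl on an aromatic nitrogen.

For the measured compounds named here, only one measured step touches a change of this kind, the addition of a chain at a saturated carbon bound to the aromatic nitrogen, an at least 1.4-fold higher number from compound 1 to compound 2 (0.15 log units; that floor lies within the scatter). That step is known only as a floor because it runs into (the limit of > 30000 nM in this assay, at which 1 of the 3 values shown sits), and its floor lies within the scatter. The evidence therefore gives no sign that removing such a chain moves the value in this assay beyond the scatter in either direction.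

Compound 4 is therefore expected to land near compound 3, at an estimated 18000 nM, with a range from 8000 nM to 40000 nM, that is an expected step of a 1.1-fold higher number from compound 3 to compound 4 (0.04 log units; within the scatter).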

Compound 4, half-maximal inhibitory concentration: 3500 nM
Compound 4: the middle estimate sits 5.1-fold (0.71 log units) above what was measured; measured number outside the range, below it.
By their numbers in this assay, from the lowest: compound 4; then compounds 3 and 1 (each within the scatter of the next). At a limit, above all of these: compound 2.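

In this assay, for the compounds shown here, putting hydrogen in place of 3,3-diethoxypropyl on the aromatic nitrogen gives a readable step for the first time at this position: a 4.7-fold lower number from compound 3 to compound 4 (0.67 log units; beyond the scatter). The earlier step on this nitrogen, an at least 1.4-fold higher number from compound 1 to compound 2 (0.15 log units; that floor lies within the scatter), could be read only as a floor, because compound 2 stands at a limit of the assay: the limit of > 30000 nM in this assay, at which 1 of the 4 values shown sits. The new pair shows that the group on this nitrogen is not neutral for the number in this assay, and that, with the longer chain on sulfur shared by compound 3 and compound 4, the bare nitrogen carries the lower number.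

This rests on a single pair, so the compounds shown leave open whether hydrogen in place of 3,3-diethoxypropyl has the same effect on the short chain on sulfur that compound 1 and compound 2 carry. They also leave open which part of the departing group matters: whether a plain propyl chain, or a propyl chain ending in an amine or a carboxylic acid, would sit with compound 3 or with compound 4.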